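The source may report more compounds than this note shows. Statements on the series, on what has been measured and on what is new or still open speak of the compounds shown alone.

Measured so far in a functional assay on HepG2 cells (Homo sapiens), read by MTT assay, with a stated time of 72 h; a lower number here means a stronger inhibitor, a higher number a weaker inhibitor:
compound 1, `O=C(Oc1ccc(Cl)cc1C(=O)Nc1ccc(Cl)c(Cl)c1)c1ccc(Br)cc1`: 2500 nM
compound 2, `Cc1ccc(C(=O)Oc2ccc(Br)cc2C(=O)Nc2ccc(C(F)(F)F)cc2)cc1`: 26800 nM

Going by the values given here, compound 1 stands lowest of the two numbers in this assay; the only other compound, compound 2, gives a higher number, and the gap between the two lies beyond the usual scatter. Among the compounds with values here, no pair of measured compounds differs in a single place, so there is no measured step to lean on.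

Compound 3, `O=C(Oc1ccc(Cl)cc1C(=O)Nc1ccc(Cl)c(Cl)c1)c1ccc([N+](=O)[O-])cc1`, is not yet measured. It differs from compound 1 by nitro in place of bromo on an aromatic carbon, para to a large group. Within the data shown here, nothing among the measured compounds shows how such a change reads in this assay. The step from compound 1 to compound 3 is therefore expected to be small, no change at the digits printed from compound 1 to compound 3 (within the scatter), and not beyond the scatter in either direction. Compound 3 is estimated at 2500 nM, with a range from 800 nM to 8000 nM.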

Compound 3, half-maximal inhibitory concentration: 3550 nM
The estimate for compound 3 lay 1.4-fold (0.15 log units) below the measured number; the measured number falls inside the stated range.
By their numbers in this assay, from the lowest: compounds 1 and 3 (each within the scatter of the next); then compound 2.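

In this assay, going by these compounds alone, the change from 4-bromophenyl to 4-nitrophenyl gives a 1.4-fold higher number from compound 1 to compound 3 (0.15 log units; within the scatter), the first step in these compounds that can be read at a single place. At this aromatic carbon, para to a large group, bromo and nitro therefore read alike, even though nitro brings three heavy atoms and two hydrogen-bond acceptors where bromo had one heavy atom and no acceptor. No evidence is at hand that bears on why this step reads as it does.

On these data alone, whether an amine, a carboxylic acid or a longer chain at this position would also read alike remains open. Also open is which of the differences between compound 1 and compound 2 lies behind their gap, since they differ in more than one place.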